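Swapping benzyl for 3-fluorophenyl on an amine nitrogen

The source may report more compounds than this note shows. Statements on the series, on what has been measured and on what is new or still open speak of the compounds shown alone.

In a functional assay on MGC-803 cells (Homo sapiens) for inhibition, read by sulforhodamine B assay (a higher number here means a weaker inhibitor, a lower number a stronger inhibitor), compound 1 `O=C1C(N2CCCCC2)=CC(=O)c2c1nc1n2[C@H]2OC[C@@H](O)[C@H]2OC1` gives > 4000 nM, which is a limit of the assay and not a number. Compound 2 `O=C1C(N2CCC2)=CC(=O)c2c1nc1n2[C@H]2OC[C@@H](O)[C@H]2OC1` gives > 16000 nM, again only a limit. Among the compounds with values here, compound 3 `O=C1C(NCc2ccccc2)=CC(=O)c2c1nc1n2[C@H]2OC[C@@H](O)[C@H]2OC1` gives 3490 nM, the only true number so far. Compound 4 `O=C1C(Nc2cccc(F)c2)=CC(=O)c2c1nc1n2[C@H]2OC[C@@H](O)[C@H]2OC1` keeps the shared core and has 3-fluorophenyl in place of benzyl on the amine nitrogen: 3-fluorophenyl in place of benzyl on an amine nitrogen. Within the data shown here, two measured steps bear on this position, an at least 1.1-fold lower number from compound 1 to compound 3 (0.05 log units; that floor lies within the scatter) and an at least 4.5-fold lower number from compound 2 to compound 3 (0.66 log units; beyond the scatter). Both replace a different amine group, so neither gives a direction for this change. The expected change is small, a 1.0-fold higher number from compound 3 to compound 4 (0.00 log units; within the scatter), with nothing beyond the scatter anticipated. Compound 4 is estimated at 3500 nM, within an expected range of 1200 nM to 10000 nM.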

Compound 4, half-maximal inhibitory concentration: 1470 nM
Estimate against measurement, compound 4: 2.4-fold (0.38 log units) above; the measured number falls inside the stated range.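

Within the data shown here, compound 4 gives the first reading at this amine nitrogen between two true numbers: a 2.4-fold lower number from compound 3 to compound 4 (0.38 log units; beyond the scatter). So replacing benzyl with 3-fluorophenyl moves the result beyond the scatter. The comparisons with the azetidin-1-yl and piperidin-1-yl groups are an at least 10-fold lower number from compound 2 to compound 4 (1.03 log units; beyond the scatter) and an at least 2.7-fold lower number from compound 1 to compound 4 (0.43 log units; beyond the scatter), and each starts from a limit of the assay, not a number.

The change adds a fluorine and removes the benzyl carbon outside the ring, and the compounds shown cannot tell which of these matters. Plain phenyl on the same nitrogen would separate the two.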